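The source may hold more compounds than are shown below. What is called first, only, known or untested is meant among the compounds shown, and "the series" means these compounds.

Working notes on a small series viewed in an ADME assay on RAW264.7 cells (Mus musculus) for cytotoxicity, read by MTT assay, with a stated time of 24 h, tested at 10 ug/mL; a higher number here means a weaker effect of the compound at the concentration tested, a lower number a stronger effect. Compound 1 `COc1ccc(/C=C/C(=O)c2ccc(OC)c(OC)c2)cc1` gives 73.9% in this assay. Compound 2 `COc1ccc(CCCc2cccc(O)c2)c(OC)c1` gives 67.9%, and compound 3 `COc1ccc(C(=O)CCc2cccc(OC)c2OC)c(O)c1` gives 92.8%. Among these three numbers compound 1 stands second highest. Its nearest neighbour is compound 2, whose number is lower by an amount within the scatter, so nothing separates compound 1 from compound 2 here. Its furthest neighbour is compound 3, whose number is higher by an amount beyond the scatter, so compound 3 shows the weaker effect of the two at the tested concentration. Going by the values given here, no two of the measured compounds differ in one place only, so no single-place step has been computed inside the measured set.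

Compound 4 `COc1ccc(/C=C/C(=O)c2ccc(OC)c(OC)c2)cc1OC` is the untested member. It differs from compound 1 in one place: methoxy in place of hydrogen on an aromatic carbon. Among the compounds with values here, with no single-place step anywhere among the measured compounds, there is nothing measured against which to size this change. The expected step, a number 1.9 percentage points lower from compound 1 to compound 4 (within the scatter), is therefore taken as none beyond the scatter in this assay, in no preferred direction. Compound 4 is accordingly estimated at 72%, with a range from 55% to 90%.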

Compound 4, a percentage reported as activity, at one concentration (the size of the read-out at that concentration, not a potency): 60.4%
The estimate for compound 4 lay 11.6 percentage points above the measured number; low and high end bracket the measured number.
By their numbers in this assay, from the lowest: compounds 4, 2 and 1 (each within the scatter of the next, the first and the last beyond it); then compound 3.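

Going by these compounds alone, this is the first single-place step. In this assay, methoxy in place of hydrogen on an aromatic carbon, ortho to a methoxy group and meta to a large group, gives a number 13.5 percentage points lower from compound 1 to compound 4 (beyond the scatter), so compound 4 shows the stronger effect of the pair at the tested concentration and this position is not silent to the change. No independent measurement bears on the origin of this step, so it stands as an observation without an assigned cause.

A single step on one core leaves open whether the size and direction belong to methoxy itself: an ethoxy group, a hydroxyl group, an amine or a fluorine on the same aromatic carbon could each separate that question from the mere presence of a substituent there. Within the data shown here, also open is whether the same methoxy change on a different core, such as that of compound 2 or compound 3, would give a step of similar direction, since the single step here speaks only for the core of compound 1.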